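Adding a sulfonyl group to compound 2

This account rests on a few compounds, and the source may have more. Where it says the series, first, only, none or still open, it means among the compounds named here.

In a functional assay on HeLa cells (Homo sapiens) for antiproliferative activity, read by MTT assay, with a stated time of 24 h (a lower number here means a stronger inhibitor, a higher number a weaker inhibitor), compound 2 (`FC(F)(F)c1ccc(-c2nn(-c3ccccc3)cc2-c2nc3ccccc3[nH]2)cc1`) gives 4670 nM. Compound 1 (`Cc1ccc(-c2nn(-c3ccccc3)cc2-c2nc3ccccc3[nH]2)cc1`) gives 4950 nM, and the two values cannot be told apart. For the measured compounds named here, the one measured step, a 1.1-fold lower number from compound 1 to compound 2 (0.03 log units; within the scatter), lies within the scatter.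

Compound 3 (`COc1ccc(S(=O)(=O)n2c(-c3cn(-c4ccccc4)nc3-c3ccc(C(F)(F)F)cc3)nc3ccccc32)cc1`) has (4-methoxyphenyl)sulfonyl in place of hydrogen on an aromatic nitrogen. Going by the values given here, the measured step changed a different place, so it gives no size for this one, and no measured compound carries a group on that nitrogen. Even so, the added group is large, and a moderate move towards a lower number is expected, though with little support and a wide range. The expected change is a 1.9-fold lower number from compound 2 to compound 3 (0.27 log units; within the scatter). Compound 3 is estimated at 2500 nM, with an expected range from 600 nM to 9000 nM.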

Compound 3, half-maximal inhibitory concentration: 250 nM
The estimate for compound 3 lay 10-fold (1.00 log units) above the measured number; measured number outside the range, below it.
By their numbers in this assay, from the lowest: compound 3; then compounds 2 and 1 (each within the scatter of the next).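

In this assay, the aromatic nitrogen proves to be a place where a substituent can shift the number well beyond the scatter: (4-methoxyphenyl)sulfonyl in place of hydrogen gives a 19-fold lower number from compound 2 to compound 3 (1.27 log units; beyond the scatter) and so far exceeds the earlier step, a 1.1-fold lower number from compound 1 to compound 2 (0.03 log units; within the scatter), which changed a different place. The hydrogen on that nitrogen is therefore not required for a low number here, since compound 3 carries a group of 11 heavy atoms there and still gives the lowest number of the three. Nothing available explains this drop.

A single step cannot show whether the sulfonyl, the benzene ring or the methoxy accounts for the change. The compounds shown leave open what a methylsulfonyl, an unsubstituted phenylsulfonyl or a benzyl group on that nitrogen would give, and whether an amine in place of the methoxy would keep the low number.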